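The compounds below may be only part of what the source reports. "The series", "measured", "known", "first", "only" and "open" are said of these compounds alone.

Among the compounds with values here, compound 1 (`O=C(O)CCCCC(CCSC(=O)c1ccccc1)SC(=O)c1ccccc1`) gives 0.77% in a functional assay on NCI-H460 cells (Homo sapiens) for inhibition, read by MTT assay, with a stated time of 24 h, tested at 1 ug/mL (on this read-out higher numbers stand for more inhibition of growth at the one concentration tested and lower numbers for less inhibition of growth), and holds the lower of the two numbers so far, while compound 2 (`CC(=O)SCCC(CCCCC(=O)Nc1ccccc1)SC(C)=O`) gives 13.1% and stands above it by more than the usual scatter. Compound 3 (`O=C(CCCCC(CCSC(=O)c1ccccc1)SC(=O)c1ccccc1)Nc1ccccc1Cl`) keeps the core of compound 1 but carries (2-chlorophenyl)amino in place of hydroxy on a carbonyl carbon. Within the data shown here, no two measured compounds differ in only one place, so the size of this change has not been seen directly. Compound 1 at 0.77% has little room to fall, and compound 2 at 13.1% shows that a higher number is reachable. In this assay the expected step is a rise, estimated at a number 14.2 percentage points higher from compound 1 to compound 3 (beyond the scatter) and so beyond the scatter. The estimate for compound 3 is 15% (expected range 3% to 40%).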

Compound 3, percent growth inhibition at one concentration: 14.4%
Estimate against measurement, compound 3: 0.6 percentage points above; measured number inside the range.
By their numbers in this assay, from the lowest: compound 1; then compounds 2 and 3 (each within the scatter of the next).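

Replacing hydroxy with (2-chlorophenyl)amino on a carbonyl carbon turns the carboxy end of compound 1 into a (2-chlorophenyl)carbamoyl end, and in this assay this gives a number 13.6 percentage points higher from compound 1 to compound 3 (beyond the scatter). Within the data shown here, this is the first change in a single place that can be read directly, and it shows that the carboxy group is not needed for growth inhibition at this concentration and that this position accepts a far larger group containing an aromatic ring. Nothing measured here explains the rise.

On these data alone, it remains open whether the ring, the chlorine or the amide nitrogen accounts for the step. Placing a plain phenylamino group or a simple amine such as methylamino on the core of compound 1 would help separate these parts.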